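Compound 3 and a change of aryl group

The source may hold more compounds than are shown below. What is called first, only, known or untested is meant among the compounds shown, and "the series" means these compounds.

Measured in a functional assay on MCF7 cells (Homo sapiens) for inhibition, read by CCK-8 assay, with a stated time of 48 h; a lower number here means a stronger inhibitor of growth, a higher number a weaker inhibitor of growth:
Compound 1 `CN1CCN(c2ccc(Nc3ncc(Cl)c(NCc4ccco4)n3)nc2)CC1`: 21300 nM
Compound 2 `Cc1cc(C)c(Nc2nc(Nc3ccc(N4CCN(C)CC4)cn3)ncc2Cl)c(C)c1`: 9470 nM

For the measured compounds named here, of the two numbers so far, the lower belongs to compound 2 at 9470 nM. Compound 3 `COc1cccc(Nc2nc(Nc3ccc(N4CCN(C)CC4)cn3)ncc2Cl)c1` keeps the shared core of compound 2 and differs in one place: 3-methoxyphenyl in place of 2,4,6-trimethylphenyl on a nitrogen on an aromatic ring. Here 3-methoxyphenyl stands in place of 2,4,6-trimethylphenyl on a nitrogen on an aromatic ring.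

Going by the values given here, only one measured change bears on this, and it falls at that same nitrogen: a 2.2-fold lower number from compound 1 to compound 2 (0.35 log units; beyond the scatter). That step is modest, and it replaced (furan-2-yl)methyl with 2,4,6-trimethylphenyl. Neither measured compound carries 3-methoxyphenyl, so the data offer no direct guide to the new group. No large move in this assay is therefore expected, and a step within the scatter seems most likely, with the direction left open. The expected change is a 1.2-fold lower number from compound 2 to compound 3 (0.07 log units; within the scatter). For compound 3 the estimated value is 8000 nM, with an expected range from 2500 nM to 25000 nM.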

Compound 3, concentration for 50% growth inhibition: 7540 nM
The estimate for compound 3 lay 1.1-fold (0.03 log units) above the measured number; measured number inside the range.
By their numbers in this assay, from the lowest: compounds 3 and 2 (each within the scatter of the next); then compound 1.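

Exchanging 2,4,6-trimethylphenyl for 3-methoxyphenyl on this nitrogen gives, in this assay, a 1.3-fold lower number from compound 2 to compound 3 (0.10 log units; within the scatter); the entering group has one hydrogen-bond acceptor where the leaving group has none, yet the two compounds read alike. The comparison with the (furan-2-yl)methyl compound gives a 2.8-fold lower number from compound 1 to compound 3 (0.45 log units; beyond the scatter), so among the three compounds shown, both groups with the aromatic ring directly on the nitrogen, in compound 2 and compound 3, give lower numbers than the group in compound 1, though all three remain in the same broad range. The data shown offer no measured explanation for either result.

Still open, from the compounds shown here alone, is whether an unsubstituted phenyl group, or a phenyl group carrying a carboxylic acid or an amine, would read like compound 2 and compound 3 at this nitrogen or would move the number beyond the scatter. The rest of the shared core is the same in all three compounds, so they do not show what replacing the chlorine or the methyl on the piperazine with, for example, a longer chain would do.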